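Methoxy to hydroxy on the shared core

The source may report more compounds than this note shows. Statements on the series, on what has been measured and on what is new or still open speak of the compounds shown alone.

In an ADME assay on L6 cells (Rattus norvegicus) for cytotoxicity (a lower number here means a stronger inhibitor, a higher number a weaker inhibitor), compound 3 `COc1cc(C2=NCCN2)ccc1-c1cc2ccc(C3=NCCN3)cc2o1` gives 4400 nM and compound 1 `c1cc(-c2cc3ccc(C4=NCCN4)cc3o2)ccc1C1=NCCN1` gives 4500 nM, the two lying within the scatter of each other. Compound 2 `N=C(N)c1ccc(O)c(-c2cc3cc(C(=N)N)ccc3o2)c1` gives only a limit in this assay, namely > 217000 nM, and no number. Among the measured compounds shown here, no single-place step joins compound 2 to the others, so it sets no size for the step considered here.

Compound 4 `Oc1cc(C2=NCCN2)ccc1-c1cc2ccc(C3=NCCN3)cc2o1` differs from compound 3 by one change hydrogen in place of methyl on an oxygen on an aromatic ring, that is, methoxy to hydroxy. For the measured compounds named here, the one measured step that bears on this change is methoxy in place of hydrogen on an aromatic carbon. Going by the values given here, it is only an indirect guide, as no measured step involves the hydroxy group itself. No step beyond the scatter is expected in this assay because a 1.0-fold lower number from compound 1 to compound 3 (0.01 log units; within the scatter) is all that the series offers on this part of the structure. The expected step is a 1.3-fold higher number from compound 3 to compound 4 (0.10 log units; within the scatter), and its direction is not firmly indicated. For compound 4 the estimated value is 5500 nM, with an expected range of 2000 nM to 16000 nM.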

Compound 4, half-maximal inhibitory concentration: > 193000 nM
Compound 4 gave a limit, no number (the forecaster's own chance of this, stated with the estimate: 5%); at least 35-fold (1.54 log units) between middle value and limit.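

In this assay, among the compounds shown here, the substituent at this position matters far more than the earlier compounds showed: hydrogen in place of methyl on the oxygen gives an at least 43-fold higher number from compound 3 to compound 4 (1.64 log units; beyond the scatter), and measured against the core without the substituent the hydroxy compound gives an at least 42-fold higher number from compound 1 to compound 4 (1.63 log units; beyond the scatter). Methoxy in place of hydrogen had left the value within the scatter, so the earlier step said nothing about the hydroxy form, which here parts clearly from both the methoxy and the hydrogen forms. Compound 4 gives > 193000 nM, a limit of the assay and not a number, so both new steps fix only a minimum size: the limit of > 193000 nM in this assay, at which 1 of the 4 values shown sits.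

The compounds shown leave open whether this large step belongs to the hydroxy group alone or would also appear with an amine or a carboxylic acid at the same position. They also leave open whether a longer chain on the oxygen, such as ethoxy, would stay with methoxy in this assay or move towards the hydroxy compound.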